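Propargyl to cyanobenzyl: reading a step from a limit

This account rests on a few compounds, and the source may have more. Where it says the series, first, only, none or still open, it means among the compounds named here.

Compound 1 `CCN(CC)c1ccc2cc(C(=O)c3ccc(N4CCN(C(=O)CN5CCNCC5)CC4)cc3)oc2c1` carries a free amine nitrogen in its outer ring, and in a functional assay on HeLa cells (Homo sapiens) for cytotoxicity, read by MTT assay, with a stated time of 48 h (on this read-out lower numbers stand for stronger inhibition and higher numbers for weaker inhibition), compound 1 gives 1350 nM. Compound 2 `CCN(CC)c1ccc2cc(C(=O)c3ccc(N4CCN(C(=O)CN5CCN(S(=O)(=O)c6ccc(C#N)cc6)CC5)CC4)cc3)oc2c1` places a (4-cyanophenyl)sulfonyl on that nitrogen, and in this assay compound 2 gives 8470 nM, which is a 6.3-fold higher number from compound 1 to compound 2 (0.80 log units; beyond the scatter). Compound 3 `C#CCN1CCN(CC(=O)N2CCN(c3ccc(C(=O)c4cc5ccc(N(CC)CC)cc5o4)cc3)CC2)CC1` carries a propargyl on the same nitrogen instead. For compound 3 this assay reports only a limit, > 40000 nM. On these numbers that amounts to an at least 29-fold higher number from compound 1 to compound 3 (1.47 log units; beyond the scatter) and an at least 4.7-fold higher number from compound 2 to compound 3 (0.67 log units; beyond the scatter), so compound 3 stands as the weakest of the three. Compound 4 `CCN(CC)c1ccc2cc(C(=O)c3ccc(N4CCN(C(=O)CN5CCN(Cc6ccc(C#N)cc6)CC5)CC4)cc3)oc2c1` differs from compound 3 in one place: 4-cyanophenyl in place of ethynyl on a saturated chain carbon bound to an amine nitrogen in a ring. Compound 2 is the nearest guide: it too carries a 4-cyanophenyl on the ring amine nitrogen, though joined through a sulfonyl rather than a saturated carbon. The change is expected to recover part of the loss seen from compound 2 to compound 3, so compound 4 is expected to show a step of an at least 3.3-fold lower number from compound 3 to compound 4 (0.52 log units; beyond the scatter). Compound 4 is therefore estimated at 12000 nM, within a range of 4000 nM to 40000 nM, with a real chance that only a limit is reported again.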

Compound 4, half-maximal inhibitory concentration: > 40000 nM
Compound 4 ended at the assay's limit; the forecaster's own chance of this, stated with the estimate: 30%; at least 3.3-fold (0.52 log units) between middle value and limit.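

Replacing the propargyl with a 4-cyanobenzyl brings no measurable number back in this assay: compound 4 gives only a limit of the assay, like compound 3, and the step between these two limits cannot be read. Joining the 4-cyanophenyl through a saturated carbon instead of a sulfonyl gives an at least 4.7-fold higher number from compound 2 to compound 4 (0.67 log units; beyond the scatter), so carrying that aromatic ring is not enough to keep the level of compound 2. Against the free amine nitrogen the change is an at least 29-fold higher number from compound 1 to compound 4 (1.47 log units; beyond the scatter), and both carbon-linked groups shown on this nitrogen now end at the same limit: the limit of > 40000 nM in this assay, at which 2 of the 4 values shown sit.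

As far as these compounds go, how far compound 3 and compound 4 lie beyond that limit stays unknown, so they cannot be ranked. Also open, from the compounds shown here alone, is whether a methyl, an acetyl or a plain benzenesulfonyl on this nitrogen would give a readable number, as the sulfonyl of compound 2 does.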